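This account rests on a few compounds, and the source may have more. Where it says the series, first, only, none or still open, it means among the compounds named here.

Compound 1 `Cc1cc(NC(=O)Cn2nnc(-c3ccccc3)n2)n(C2CCCCC2)n1`: 96 nM
Compound 2 `Cc1cc(NC(=O)Cn2nnc(-c3ccccc3)n2)n(C2CCOCC2)n1`: 435 nM
Compound 3 `Cc1cc(NC(=O)Cn2nnc(-c3ccccc3)n2)n(C2CCS(=O)(=O)C2)n1`: 1030 nM

The three measured compounds share one core and differ only in the group attached to an aromatic nitrogen of that core. In an assay on HEK293 cells for activation of Kir3.1/Kir3.2 (Homo sapiens), read by thallium flux (a higher number here means that more compound is needed for the effect, a lower number that less compound is needed), compound 3 gives the highest number of the three. Its nearest neighbour is compound 2, with the modest step of a 2.4-fold higher number from compound 2 to compound 3 (0.37 log units; beyond the scatter); furthest away is compound 1, with the large step of an 11-fold higher number from compound 1 to compound 3 (1.03 log units; beyond the scatter). Compound 1, which carries cyclohexyl at that position, therefore needs the least compound of the three.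

Compound 4 `Cc1cc(NC(=O)Cn2nnc(-c3ccccc3)n2)n(Cc2ccccc2)n1` has not yet been measured. It differs from compound 3 in one place: benzyl in place of 1,1-dioxothiolan-3-yl on an aromatic nitrogen. The group that enters has a ring of carbon only, and the compound with a carbon-only ring at this position, compound 1, gives the lowest number seen so far. Among the compounds with values here, the steps that bear on the change are an 11-fold higher number from compound 1 to compound 3 (1.03 log units; beyond the scatter) and a 2.4-fold higher number from compound 2 to compound 3 (0.37 log units; beyond the scatter), both running toward higher numbers as the ring group gains hetero atoms. Going the other way, a step to a lower number is expected, probably large rather than modest. The estimate for compound 4 in this assay is 200 nM, expected to lie between 60 nM and 700 nM. That estimate corresponds to an expected step of a 5.2-fold lower number from compound 3 to compound 4 (0.71 log units; beyond the scatter).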

Compound 4, half-maximal effective concentration: 495 nM
Compound 4: middle estimate off by 2.5-fold (0.39 log units), on the low side, within the range that was stated.
By their numbers in this assay, from the lowest: compound 1; then compounds 2 and 4 (each within the scatter of the next); then compound 3.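

In this assay, a ring of carbon only at this position is not enough to give the low number of compound 1: cyclohexyl and benzyl both lack hetero atoms, yet the change between them is a 5.2-fold higher number from compound 1 to compound 4 (0.71 log units; beyond the scatter). Benzyl does give a lower number than 1,1-dioxothiolan-3-yl, but the change is only a 2.1-fold lower number from compound 3 to compound 4 (0.32 log units; beyond the scatter), well short of the gap that separates the cyclohexyl and 1,1-dioxothiolan-3-yl compounds. The comparison with oxan-4-yl, which has an oxygen in its ring, is a 1.1-fold higher number from compound 2 to compound 4 (0.06 log units; within the scatter), so these two groups cannot be told apart here, and compound 4 goes against the earlier impression that the number simply falls as hetero atoms leave the ring group.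

Nothing presented here explains why these groups differ. The compounds shown leave open whether the low number of compound 1 belongs to the non-aromatic carbon ring in general, as cyclopentyl or cycloheptyl could show, and whether a phenyl set directly on the ring nitrogen or a longer chain such as phenethyl would behave like benzyl.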